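Moving the methyl group from 2-methylphenyl to 3-methylphenyl

The source may report more compounds than this note shows. Statements on the series, on what has been measured and on what is new or still open speak of the compounds shown alone.

Compound 1 `COc1ccc(C2=NO[C@]3(C2)C(=O)O[C@@H]2[C@H]3CC[C@H](C)[C@]3(O)C=CC(=O)[C@@]23C)cc1OC`, compound 2 `C[C@H]1CC[C@@H]2[C@@H](OC(=O)[C@]23CC(c2cccc([N+](=O)[O-])c2)=NO3)[C@]2(C)C(=O)C=C[C@@]12O` and compound 3 `Cc1ccccc1C1=NO[C@]2(C1)C(=O)O[C@@H]1[C@H]2CC[C@H](C)[C@]2(O)C=CC(=O)[C@@]12C` share one core and differ only in the substituted phenyl group attached to it. In a functional assay on PC-3 cells (Homo sapiens) for cytotoxicity, read by sulforhodamine B assay, with a stated time of 48 h (on this read-out higher numbers stand for weaker inhibition and lower numbers for stronger inhibition), compound 1 gives 25000 nM, compound 2 gives 55000 nM and compound 3 gives 10000 nM. Compound 3 therefore has the lowest number of the three, meaning the strongest inhibition so far, though all three values are high.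

The next compound, compound 4 `Cc1cccc(C2=NO[C@]3(C2)C(=O)O[C@@H]2[C@H]3CC[C@H](C)[C@]3(O)C=CC(=O)[C@@]23C)c1`, differs from compound 3 at a single place, with 3-methylphenyl in place of 2-methylphenyl on a carbon with a double bond to nitrogen.

Three measured steps change a group at this same place. They are a 2.5-fold lower number from compound 1 to compound 3 (0.40 log units; beyond the scatter), a 5.5-fold lower number from compound 2 to compound 3 (0.74 log units; beyond the scatter) and a 2.2-fold higher number from compound 1 to compound 2 (0.34 log units; beyond the scatter). All three are modest, although each lies beyond the scatter. None of them shows what happens when only a methyl group changes its place on the phenyl ring, so they offer only a rough guide. As compound 3 already sits lowest at 10000 nM, a small move toward a higher number in this assay is expected, and the estimated change is a 1.5-fold higher number from compound 3 to compound 4 (0.18 log units; within the scatter). For compound 4 the estimated value is 15000 nM, with an expected range from 6000 nM to 40000 nM.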

Compound 4, half-maximal inhibitory concentration: 66600 nM
For compound 4 the middle estimate is 4.4-fold (0.65 log units) below the measured one; the whole stated range lies below it.
By their numbers in this assay, from the lowest: compound 3; then compound 1; then compounds 2 and 4 (each within the scatter of the next).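

Compounds 3 and 4 contain the same atoms. a 6.7-fold higher number from compound 3 to compound 4 (0.82 log units; beyond the scatter) in this assay isolates the effect of moving the methyl group around the phenyl ring, something the earlier swaps of whole substituted phenyl groups could not do. Here, the placement of one small group on this ring changes the number beyond the usual scatter, and the step of a 2.7-fold higher number from compound 1 to compound 4 (0.43 log units; beyond the scatter) shows that 3-methylphenyl gives weaker inhibition than 3,4-dimethoxyphenyl, whereas 2-methylphenyl gave stronger inhibition. In contrast, a 1.2-fold higher number from compound 2 to compound 4 (0.08 log units; within the scatter) shows no clear difference between the methyl group of 3-methylphenyl and the nitro group of 3-nitrophenyl, so these two compounds cannot be ranked in this assay.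

The compounds shown leave open whether the advantage of compound 3 is specific to methyl or would persist with a methoxy group, an amine or a longer chain such as ethyl at the same ring carbon, and how 4-methylphenyl would compare. Nothing available here explains why the methyl group's place on the ring matters.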